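From Methylamino to Cyclohexylamino at the Assay Limit

This account rests on a few compounds, and the source may have more. Where it says the series, first, only, none or still open, it means among the compounds named here.

Compound 3 `CNc1cc(Cl)c(C(=O)Nc2ccc(O)c(C(C)(C)C)c2)c(Cl)c1` shares its core with compound 1 `CC(C)(C)c1cc(NC(=O)c2c(Cl)cc(N)cc2Cl)ccc1O` and compound 2 `CC(C)(C)c1cc(NC(=O)c2c(Cl)cc(NCc3ccncc3)cc2Cl)ccc1O`. In an ADME assay on a cell-free system (serum) for metabolic stability (a lower number here means that the compound disappears faster, a higher number that the compound lasts longer), compound 3 gives > 1 h, which is a limit and not a number. Compound 1 gives > 1 h, also a limit. Compound 2 gives > 1 h, again a limit. Compound 4 `CC(C)(C)c1cc(NC(=O)c2c(Cl)cc(NC3CCCCC3)cc2Cl)ccc1O` carries cyclohexyl in place of methyl on a nitrogen on an aromatic ring. For the measured compounds named here, the steps that bear on this change are a step that the two limits leave unreadable from compound 1 to compound 3, a step that the two limits leave unreadable from compound 1 to compound 2 and a step that the two limits leave unreadable from compound 2 to compound 3, so they give no measured size. The expected change is a step that the limit leaves unreadable from compound 3 to compound 4, with no direction expected beyond the scatter. For compound 4 the estimated half-life is 2 h, with an expected range of 1 h to 8 h.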

Compound 4, half-life: > 1 h
Compound 4: a limit, no number (the forecaster's own chance of this, stated with the estimate: 80%); the middle value lies beyond the limit too.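

No new step can be read in this assay between compound 4 and compound 1, compound 2 or compound 3, because all four share one limit: the limit of > 1 h in this assay, at which 4 of the 4 values shown sit. The compounds shown leave open how long each actually lasts beyond that limit.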